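Urea to Amide: Predicting Compound 4 Potency

The compounds below may be only part of what the source reports. "The series", "measured", "known", "first", "only" and "open" are said of these compounds alone.

Compound 2 `CCCNC(=O)Nc1c(OCCCn2cnc(-c3ccccc3)c2)cccc1N(C)C` gives 660 nM in an assay for inhibition of acyl-CoA:cholesterol acyltransferase (Oryctolagus cuniculus), using microsomes; a lower number here means a stronger inhibitor, a higher number a weaker inhibitor. Compound 1 `CCNC(=O)Nc1c(OCCCn2cnc(-c3ccccc3)c2)cccc1N(C)C` gives 870 nM, and the step of a 1.3-fold lower number from compound 1 to compound 2 (0.12 log units; within the scatter) lies within the scatter. Compound 3 `CN(C)c1cccc(OCCCn2cnc(-c3ccccc3)c2)c1NC(=O)NC1CCCCC1` gives 73 nM, so compound 2 stands second highest of the three numbers, with the step of a 9.0-fold lower number from compound 2 to compound 3 (0.96 log units; beyond the scatter) setting it clearly apart from compound 3. Compound 4 `CCCCCC(=O)Nc1c(OCCCn2cnc(-c3ccccc3)c2)cccc1N(C)C` differs from compound 2 by pentyl in place of propylamino on a carbonyl carbon. Among the measured compounds shown here, no measured step changes the carbonyl carbon's neighbour; the measured steps of a 1.3-fold lower number from compound 1 to compound 2 (0.12 log units; within the scatter) and a 12-fold lower number from compound 1 to compound 3 (1.08 log units; beyond the scatter) only vary the group on the amide-type nitrogen. Compound 4 is therefore expected to give 700 nM, within 200 nM to 2500 nM, a step estimated as a 1.1-fold higher number from compound 2 to compound 4 (0.03 log units; within the scatter).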

Compound 4, half-maximal inhibitory concentration: 200 nM
Beside the measured number, compound 4's estimate is 3.5-fold (0.54 log units) above it; measured number inside the range.
By their numbers in this assay, from the lowest: compound 3; then compound 4; then compounds 2 and 1 (each within the scatter of the next).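

Placing pentyl on the carbonyl carbon in place of propylamino removes a hydrogen-bond donor and gives a 3.3-fold lower number from compound 2 to compound 4 (0.52 log units; beyond the scatter) in this assay, the first change shown at this position. Pentyl in place of ethylamino gives a 4.4-fold lower number from compound 1 to compound 4 (0.64 log units; beyond the scatter), so the nitrogen at this place is not required for inhibition, yet pentyl in place of cyclohexylamino goes the other way, with a 2.7-fold higher number from compound 3 to compound 4 (0.44 log units; beyond the scatter). No measurement shown explains these shifts.

Open, going by these compounds, is how a shorter or longer chain on this carbonyl carbon would compare with pentyl. Also open, on these data alone, is what a cyclohexyl ring or a terminal amine placed directly there would do.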